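From Ethoxy to Allyloxy on a Shared Core

The compounds below may be only part of what the source reports. "The series", "measured", "known", "first", "only" and "open" are said of these compounds alone.

Measured so far:
compound 1 `CC(C)COc1ccc2c(Cl)ccnc2c1` gives 2250 nM
compound 2 `CCOc1ccc2c(Cl)ccnc2c1` gives 2660 nM

Both numbers come from a functional assay on HepG2 cells (Homo sapiens) for cytotoxicity, read by MTT assay, with a stated time of 48 h; a lower number here means a stronger inhibitor, a higher number a weaker inhibitor. Compound 2 holds the higher of the two numbers, though its nearest neighbour is compound 1 and the gap between them is small: a 1.2-fold higher number from compound 1 to compound 2 (0.07 log units; within the scatter) describes a change of methyl in place of isopropyl on a saturated chain carbon bound to an oxygen on an aromatic ring.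

Compound 3 `C=CCOc1ccc2c(Cl)ccnc2c1` is not yet measured. It differs from compound 2 by vinyl in place of methyl on a saturated chain carbon bound to an oxygen on an aromatic ring, which, cut one bond further out, reads ethyl to allyl, or ethoxy to allyloxy.

For the measured compounds named here, the only step known here changed the same chain carbon and stayed within the scatter. No basis exists for expecting a larger move now, so the expected step in this assay is a 1.1-fold lower number from compound 2 to compound 3 (0.04 log units; within the scatter), with no clear direction. Compound 3 is therefore estimated at 2400 nM, within a range from 1200 nM to 5000 nM.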

Compound 3, half-maximal inhibitory concentration: 2770 nM
Beside the measured number, compound 3's estimate is 1.2-fold (0.06 log units) below it; the range from low to high includes it.
By their numbers in this assay, from the lowest: compounds 1, 2 and 3 (each within the scatter of the next).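

In this assay, a double bond in the chain on this oxygen leaves the reading within the scatter: the change from ethoxy to allyloxy gives (a 1.0-fold higher number from compound 2 to compound 3 (0.02 log units; within the scatter)). Setting the vinyl end against the isopropyl end gives the same picture (a 1.2-fold higher number from compound 1 to compound 3 (0.09 log units; within the scatter)), so all three chain ends now shown at this saturated chain carbon read alike in this test, and an unsaturated end is no exception. Nothing at hand offers an explanation for this flat result.

As far as these compounds go, all three compounds carry only small carbon groups at this place, so it remains open whether any group here can move the number beyond the scatter. A much longer chain, an amine or a carboxylic acid on the same carbon could read quite differently, and these three compounds say nothing about them.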